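Isopropyl on the benzyl arm: a step near the ceiling

The compounds below may be only part of what the source reports. "The series", "measured", "known", "first", "only" and "open" are said of these compounds alone.

Compound 1 `CC(=O)OC[C@H]1O[C@@H](n2cc(-c3cn(Cc4ccccc4)nn3)c(=O)[nH]c2=O)C[C@@H]1OC(C)=O`: 92.3%
Compound 2 `CCCCCCCCc1cc(-c2cn([C@H]3C[C@H](O)[C@@H](CO)O3)c(=O)[nH]c2=O)on1`: 88.2%
Compound 3 `CC(=O)OC[C@H]1O[C@@H](n2cc(-c3cc(-c4ccccc4)no3)c(=O)[nH]c2=O)C[C@@H]1OC(C)=O`: 92.2%

Of the compounds shown here, three have been measured in a functional assay on HCT-15 cells (Homo sapiens) for cytotoxicity, read by sulforhodamine B assay, tested at 10 uM; on this read-out lower numbers stand for less inhibition and higher numbers for more inhibition at the one concentration tested (going by the name of the read-out). Compound 1 gives 92.3%, compound 2 gives 88.2% and compound 3 gives 92.2%. The number for compound 1 sits alongside those of compound 3 and compound 2; its gap to compound 3 and its gap to compound 2 both lie within the usual scatter of this kind of measurement, so none of the three can be told apart from the others. All three numbers lie close to the top of what the read-out can show.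

Compound 4 `CC(=O)OC[C@H]1O[C@@H](n2cc(-c3cn(Cc4ccc(C(C)C)cc4)nn3)c(=O)[nH]c2=O)C[C@@H]1OC(C)=O` has not been measured. It keeps the core of compound 1 and differs in one place: isopropyl in place of hydrogen on an aromatic carbon. Within the data shown here, no pair of measured compounds shows this kind of change, so there is no measured step to lean on. Because compound 1 already gives 92.3%, there is little room for a larger number, and a change this small is expected to leave the read-out where it is, with no step beyond the scatter. The expected step in this assay from compound 1 to compound 4 is a number 2.3 percentage points lower from compound 1 to compound 4 (within the scatter). Compound 4 is estimated to give 90%, with a range from 80% to 97%.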

Compound 4, a percentage reported as inhibition, at one concentration (the size of the read-out at that concentration, not a potency): 96.5%
Compound 4: middle estimate off by 6.5 percentage points, on the low side; measured number inside the range.
By their numbers in this assay, from the lowest: compounds 2, 3, 1 and 4 (each within the scatter of the next).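

In this assay, placing isopropyl on the aromatic carbon para to a large group, which turns benzyl into 4-isopropylbenzyl, gives a number 4.2 percentage points higher from compound 1 to compound 4 (within the scatter), the first step measured between two compounds that differ in one place. This shows that the aromatic ring of the benzyl arm can carry this branched group of three carbons with no change beyond the scatter, although a read-out this close to its ceiling has little room to show a further rise. No accompanying measurement bears on this result, so the step comes with no explanation.

As far as these compounds go, it remains open whether this position would give the same picture with an amine, a carboxylic acid or a longer chain in place of isopropyl, since a single pair shows only one substitution at one place on the ring. Both compound 1 and compound 4 were read at one concentration, so any difference in the size of their effect could only emerge from readings across a range of concentrations, where the numbers fall away from the top of the scale.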